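Chloro for Methyl on the Aryl Ring of Compound 2

The source may report more compounds than this note shows. Statements on the series, on what has been measured and on what is new or still open speak of the compounds shown alone.

Compound 1 `COc1ccc(-c2cc(=O)c3c(O)cc(OCCCCN4CCN(C)CC4)c(OC)c3o2)cc1` and compound 2 `COc1c(OCCCCN2CCN(C)CC2)cc(O)c2c(=O)cc(-c3ccc(C)cc3)oc12` share one core and differ only in the group on the six-membered aromatic ring of carbon only. In a functional assay on A549 cells (Homo sapiens) for cytotoxicity, read by MTT assay, with a stated time of 72 h (on this read-out lower numbers stand for stronger inhibition and higher numbers for weaker inhibition), compound 1 gives 2320 nM. In this assay compound 2 gives 3810 nM. The step of a 1.6-fold higher number from compound 1 to compound 2 (0.22 log units; within the scatter) lies within the scatter. Of the two measured numbers compound 2 stands highest, with compound 1 nearest, and since their step is within the scatter the two cannot be told apart.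

Compound 3 `COc1c(OCCCCN2CCN(C)CC2)cc(O)c2c(=O)cc(-c3ccc(Cl)cc3)oc12` carries the next change: chloro in place of methyl on an aromatic carbon. For the measured compounds named here, no measured pair tests chloro at that aromatic carbon. Going by the values given here, the only step touching the same carbon is a 1.6-fold higher number from compound 1 to compound 2 (0.22 log units; within the scatter), where methyl replaced methoxy and the number barely moved. With that single step as guide, compound 3 is expected to show no shift beyond the scatter in this assay, the expected step being a 1.1-fold lower number from compound 2 to compound 3 (0.04 log units; within the scatter). Compound 3 is therefore estimated at 3500 nM, with a range from 1500 nM to 8000 nM.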

Compound 3, half-maximal inhibitory concentration: 1430 nM
The estimate for compound 3 lay 2.4-fold (0.39 log units) above the measured number, and the stated range ends above it.
By their numbers in this assay, from the lowest: compounds 3, 1 and 2 (each within the scatter of the next, the first and the last beyond it).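

In this assay, for the compounds shown here, chloro in place of methyl on the aromatic carbon para to a large group gives the first step at this position that lies beyond the scatter, a modest one (a 2.7-fold lower number from compound 2 to compound 3 (0.43 log units; beyond the scatter)). The exchange of methoxy for chloro at the same carbon does not separate the two compounds (a 1.6-fold lower number from compound 1 to compound 3 (0.21 log units; within the scatter)), so among the three groups tested here only chloro and methyl can be told apart, while methoxy cannot be distinguished from either. Nothing available on these compounds explains the difference between the 4-methylphenyl and 4-chlorophenyl compounds, and the step stands as an observation only.

The compounds shown leave open how fluoro, bromo, nitrile or an amine on this same carbon would read in this assay, and so whether the gain belongs to chloro alone or extends to other groups. From the compounds shown here alone, all three numbers also come from a single cell line, so it remains open whether the gap between chloro and methyl would hold in other cells.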